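This account rests on a few compounds, and the source may have more. Where it says the series, first, only, none or still open, it means among the compounds named here.

Measured in an ADME assay on HepG2 cells (Homo sapiens) for cytotoxicity, read by trypan blue exclusion, with a stated time of 48 h, in the presence of a further agent that is not named here; a higher number here means that more compound is tolerated, a lower number that less compound is tolerated:
Compound 1 `COc1ccccc1NC(=O)COc1cc(C)nc2ccc(C(F)(F)F)cc12`: > 128000 nM, a limit and not a number.
Compound 2 `COc1ccc2nc(C)cc(OCC(=O)Nc3ccc(Cl)cc3)c2c1`: 89900 nM.
Compound 3 `COc1ccccc1NC(=O)COc1cc(C)nc2ccccc12`: 43900 nM.

Compound 2 gives 89900 nM and compound 3 gives 43900 nM, the lower of the two numbers, with the gap just beyond the scatter. Compound 1 stands at the limit of > 128000 nM in this assay, at which 1 of the 3 values shown sits.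

Compound 4 `COc1ccccc1NC(=O)COc1cc(C)nc2ccc(C)cc12` has methyl in place of hydrogen on an aromatic carbon of compound 3 (methyl in place of hydrogen on an aromatic carbon). For the measured compounds named here, one measured step bears on this change: an at least 2.9-fold lower number from compound 1 to compound 3 (0.46 log units; beyond the scatter). Going by these compounds, that step also ends at compound 3, and its full size remains open since compound 1 is only a limit. Methyl is a different group from trifluoromethyl, so the same direction is expected in this assay, with a smaller size that may stay within the scatter. The expected change is a 1.5-fold higher number from compound 3 to compound 4 (0.17 log units; within the scatter). For compound 4 the estimated value is 65000 nM, with an expected range of 32000 nM to 128000 nM.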

Compound 4, half-maximal cytotoxic concentration: > 74000 nM
Compound 4 was reported as a limit; the forecaster's own chance of this, stated with the estimate: 12%; middle value at least 1.1-fold (0.05 log units) from the limit.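

In this assay, methyl in place of hydrogen on this aromatic carbon gives an at least 1.6-fold higher number from compound 3 to compound 4 (0.22 log units; that floor lies within the scatter), so the floor of this step does not by itself separate compound 4 from compound 3. Compound 4 is reported only as a limit: the limit of > 74000 nM in this assay, at which 1 of the 4 values shown sits. Methyl and trifluoromethyl at this position both stand on the higher side of compound 3, but only the trifluoromethyl step, an at least 2.9-fold lower number from compound 1 to compound 3 (0.46 log units; beyond the scatter), is printed as beyond the scatter; compound 1 and compound 4 are both limits, and the step between them cannot be read.

Going by these compounds, the actual tolerated concentrations of compound 1 and compound 4 remain open, and so does any ranking of methyl against trifluoromethyl. Also open, on these data alone, is how an amine or a carboxylic acid on this aromatic carbon would read in this assay.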